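This account rests on a few compounds, and the source may have more. Where it says the series, first, only, none or still open, it means among the compounds named here.

Measured in a functional assay on Raji cells (Homo sapiens) for antiproliferative activity, read by CCK-8 assay, with a stated time of 72 h, tested at 40 uM; a higher number here means more inhibition at the concentration tested (going by the name of the read-out), a lower number less inhibition:

- compound 1 `CCOC(=O)c1sc(-c2cccc(NC(=O)c3ccc(C(F)(F)F)cc3)c2)nc1Nc1ccc(N2CCN(C)CC2)cc1`: 33%
- compound 2 `CCOC(=O)c1sc(-c2cccc(NC(=O)c3ccc(F)cc3)c2)nc1Nc1ccc(N2CCN(C)CC2)cc1`: 16.8%
- compound 3 `CCOC(=O)c1sc(-c2cccc(NC(=O)c3ccc(C(F)(F)F)cn3)c2)nc1Nc1ccc(N2CCN(C)CC2)cc1`: 20.8%

Compound 3 sits second highest of the three numbers. Its nearest neighbour is compound 2, and the two values lie within the usual scatter of each other. Its furthest neighbour is compound 1, reached by a number 12.2 percentage points lower from compound 1 to compound 3 (beyond the scatter).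

Compound 4 `CCOC(=O)c1sc(-c2cccc(NC(=O)c3ccco3)c2)nc1Nc1ccc(N2CCN(C)CC2)cc1` carries a single change: furan-2-yl in place of 5-(trifluoromethyl)pyridin-2-yl on a carbonyl carbon. The two earlier exchanges at this carbonyl carbon were a number 12.2 percentage points lower from compound 1 to compound 3 (beyond the scatter) and a number 4 percentage points higher from compound 2 to compound 3 (within the scatter), so swapping the aryl group here has moved the read-out only modestly. Loss of the trifluoromethyl group, seen in a number 16.2 percentage points lower from compound 1 to compound 2 (beyond the scatter), went with a lower number.

Compound 4 is therefore expected to come out somewhat lower in this assay, with a number 6.8 percentage points lower from compound 3 to compound 4 (within the scatter). Compound 4 is estimated at 14%, within a range from 4% to 26%.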

Compound 4, a percentage reported as inhibition, at one concentration (the size of the read-out at that concentration, not a potency): 87.6%
Compound 4: the middle estimate sits 73.6 percentage points below what was measured; measured number outside the range, above it.
By their numbers in this assay, from the lowest: compounds 2 and 3 (each within the scatter of the next); then compound 1; then compound 4.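

In this assay, furan-2-yl on this carbonyl carbon gives a number 66.8 percentage points higher from compound 3 to compound 4 (beyond the scatter) and a number 70.8 percentage points higher from compound 2 to compound 4 (beyond the scatter) and a number 54.6 percentage points higher from compound 1 to compound 4 (beyond the scatter) whichever six-membered aromatic ring it replaces. Going by these compounds alone, the group here can therefore change the read-out far more than the earlier exchanges showed, and compound 4 reaches the top number without the trifluoromethyl group that went with the higher number among the earlier compounds. Nothing available explains why this exchange has so large an effect.

From the compounds shown here alone, it remains open whether the gain belongs to furan-2-yl alone or extends to other five-membered aromatic rings, such as thiophen-2-yl on the same carbonyl carbon. Going by these compounds, it is also open whether a furan ring carrying a methyl group would keep the high number.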